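Swapping the Urea-Side Aryl Amine for a Trifluoromethylphenyl

The source may hold more compounds than are shown below. What is called first, only, known or untested is meant among the compounds shown, and "the series" means these compounds.

Measured compounds:
Compound 1, `O=C(Nc1cccc(-n2cc(-c3ccncc3)c(-c3cc(O)cc(Cl)c3)n2)c1)Nc1ccc(Cl)c(Cl)c1`: -45%
Compound 2, `COc1cc(Cl)cc(-c2nn(-c3cccc(NC(=O)Nc4ccc(Cl)c(Cl)c4)c3)cc2-c2ccncc2)c1`: -24%

Both compounds were tested in a functional assay on Malme-3M cells (Homo sapiens) for inhibition, read by sulforhodamine B assay, with a stated time of 48 h, tested at 100 uM; on this read-out lower numbers stand for a stronger effect and higher numbers for a weaker effect at the one concentration tested. Compound 2 stands highest of the two numbers, its nearest neighbour being compound 1, which lies lower by a step that is beyond the scatter: a number 21 percentage points higher from compound 1 to compound 2 (beyond the scatter).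

Compound 3, `COc1cc(Cl)cc(-c2nn(-c3cccc(NC(=O)c4cccc(C(F)(F)F)c4)c3)cc2-c2ccncc2)c1`, has not yet been measured. It differs from compound 2 in one place: 3-(trifluoromethyl)phenyl in place of (3,4-dichlorophenyl)amino on a carbonyl carbon. The change sits on a carbonyl carbon whose other neighbour is an amide-type nitrogen.

Within the data shown here, no measured step bears on this change. Among the measured compounds shown here, the only step seen so far concerns a methyl in place of hydrogen on an oxygen on an aromatic ring, and it says nothing about the group attached to the carbonyl carbon. The expectation for compound 3 in this assay must therefore rest on compound 2 alone, and no step beyond the scatter is assumed in either direction, while the uncertainty is wide.

Compound 3 is expected to give about -22% in this assay, within a range from -60% to 15%, an estimated step of a number 2 percentage points higher from compound 2 to compound 3 (within the scatter).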

Compound 3, a percentage reported as activity, at one concentration (the size of the read-out at that concentration, not a potency): 55%
Estimate against measurement, compound 3: 77 percentage points below; the whole stated range lies below it.
By their numbers in this assay, from the lowest: compound 1; then compound 2; then compound 3.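

In this assay, the group on the carbonyl carbon emerges as a place of large effect: 3-(trifluoromethyl)phenyl in place of (3,4-dichlorophenyl)amino gives a number 79 percentage points higher from compound 2 to compound 3 (beyond the scatter) and moves the read-out to the weak side, with compound 3 at 55% and so on the opposite side of zero from the two earlier compounds. This step is rated large, whereas the change on the aromatic oxygen, a number 21 percentage points higher from compound 1 to compound 2 (beyond the scatter), is rated modest, so the carbonyl substituent matters more here than the methyl on that oxygen. Two things change together in this swap, the nitrogen on the carbonyl carbon with its hydrogen-bond donor and the substitution of the aromatic ring, and no available measurement gives a cause for the step.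

The compounds shown do not separate these two parts of the change, so it stays open whether (3-(trifluoromethyl)phenyl)amino would behave like the group that left or like the group that entered. Going by these compounds, it is equally open how a 3,4-dichlorophenyl attached directly to the carbonyl carbon, or a piperidine or a short alkyl amine in that place, would read out.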